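Swapping Methyl for Nitro on the Aromatic Ring

The source may hold more compounds than are shown below. What is called first, only, known or untested is meant among the compounds shown, and "the series" means these compounds.

Three small compounds built on one shared core have been tested in a functional assay on the whole organism for inhibition, with Rattus norvegicus as the target, read by paw edema, with a stated time of 30 min, at a dose of 40 mg/kg by the oral route; a higher number here means a stronger effect of the compound at the dose given, a lower number a weaker effect. Compound 1 `Brc1ccccc1OCC1=NCCO1` gives 29.1%. Compound 2 `Cc1cc(OCC2=NCCO2)ccc1Cl` gives 45.4%, and compound 3 `Cc1cccc(OCC2=NCCO2)c1` gives 44.6%. Compound 3 thus sits alongside compound 2, their numbers separated by less than the usual scatter, and both stand clearly above compound 1, whose number lies beyond the scatter below that of compound 3. Within the data shown here, the single measured step between close neighbours, a number 0.8 percentage points lower from compound 2 to compound 3 (within the scatter), is a change that hardly moved the read-out.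

Compound 4 `O=[N+]([O-])c1cccc(OCC2=NCCO2)c1` is the next compound to be considered. Its difference from compound 3 is nitro in place of methyl on an aromatic carbon. Among the measured compounds shown here, no measured step exchanges a methyl for a nitro, so the step from compound 2 to compound 3 is the only guide, and it bears on this change only loosely: it shows that taking one small substituent off the ring left the read-out nearly where it was. On that basis a step of modest size is expected, a number 6.6 percentage points lower from compound 3 to compound 4 (within the scatter), with no firmly foreseeable direction. For compound 4 the estimated value is 38%, with a range from 24% to 52%.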

Compound 4, a percentage reported as inhibition, in the whole organism at one dose (the size of the read-out at that dose, not a potency): 29.4%
Compound 4: the middle estimate sits 8.6 percentage points above what was measured; the measured number falls inside the stated range.
By their numbers in this assay, from the lowest: compounds 1 and 4 (each within the scatter of the next); then compounds 3 and 2 (each within the scatter of the next).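

The methyl-bearing ring carbon turns out to matter in this assay: the exchange of methyl for nitro gives a number 15.2 percentage points lower from compound 3 to compound 4 (beyond the scatter), whereas the earlier step, a number 0.8 percentage points lower from compound 2 to compound 3 (within the scatter), changed a chloro group and left this carbon untouched. This is therefore the first sign that the read-out responds to what sits at this place on the ring, at least when nitro replaces methyl. The swap changes several things at once, since nitro has more heavy atoms than methyl and brings hydrogen-bond acceptors where methyl has none, and no available measurement explains which of these differences goes with the lower number.

The compounds shown leave open how other groups on this carbon would behave, such as an amine, a methoxy group or a carboxylic acid, and whether a smaller group containing nitrogen or oxygen would give a number closer to that of methyl or of nitro. They also leave open whether the same swap would have a similar effect with the chloro group of compound 2 in place, and how the pair would compare at doses other than the single one used here.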